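This account rests on a few compounds, and the source may have more. Where it says the series, first, only, none or still open, it means among the compounds named here.

Working notes on the series. In a physicochemical assay for acid dissociation, compound 3 `COc1ccc(F)cc1CNCCCNc1ccnc2cc(-c3ccc(C(C)(C)C)cc3)ccc12` gives 9.47. In the same assay compound 2 `COc1ccc(-c2ccc3c(NCCCNCc4cc(F)ccc4OC)ccnc3c2)cc1` gives 9.47, so the two coincide at the digits shown. Compound 1 `COc1cccc(CNCCCNc2ccnc3cc(Oc4ccccc4)ccc23)c1O` gives 9.28, and the gap between compound 1 and compound 3 lies within the scatter. Among the compounds with values here, the one measured step in this set, no change at the digits printed from compound 2 to compound 3 (within the scatter), concerns the substituent on the aromatic carbon of the fused system and left the read-out unchanged.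

Compound 4 `COc1ccc(F)cc1CNCCCNc1ccnc2cc(Oc3ccccc3)ccc12` differs from compound 3 by phenoxy in place of 4-(tert-butyl)phenyl on an aromatic carbon. The step of no change at the digits printed from compound 2 to compound 3 (within the scatter) bears on this change directly and was flat. Compound 1, which carries phenoxy at the same place, gives 9.28, which sits within the scatter of compound 3. No step beyond the scatter is therefore expected in this assay; the expected step is a number 0.07 log units lower from compound 3 to compound 4 (within the scatter). Compound 4 is estimated at 9.4, with a range from 9.1 to 9.7.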

Compound 4, acid dissociation constant: 9.28
The estimate for compound 4 lay 0.12 log units above the measured number; the range from low to high includes it.
By their numbers in this assay, from the lowest: compounds 1, 4, 2 and 3 (each within the scatter of the next).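

In this assay, phenoxy in place of 4-(tert-butyl)phenyl gives a number 0.19 log units lower from compound 3 to compound 4 (within the scatter), and phenoxy in place of 4-methoxyphenyl gives a number 0.19 log units lower from compound 2 to compound 4 (within the scatter), so this aromatic carbon has now carried a group with an oxygen acceptor as well as two substituted phenyl groups without a step beyond the scatter. Within the data shown here, with phenoxy held fixed, the first change at a second place, 5-fluoro-2-methoxyphenyl in place of 2-hydroxy-3-methoxyphenyl on a saturated chain carbon bound to an amine nitrogen, gives no change at the digits printed from compound 1 to compound 4 (within the scatter) and is also flat. No supporting data are at hand to account for this flatness.

The compounds shown leave open whether an amine or a carboxylic acid on this aromatic carbon would give a step beyond the scatter in this assay at all. The same question stands for a longer chain in place of the saturated chain of the shared core.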